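Aryl replacement on the shared core: outlook for compound 3

A few compounds are considered here, and "the series" means these few. Any claim that something is new, unique, unknown or untested is made for them only; others in the source may bear on it.

Measured so far:
compound 1, `CC1(Cc2ccccc2)CC(S(=O)(=O)c2cccc(C(F)(F)F)c2)=C(c2ccc(/C(N)=N\O)cc2)O1`, 14500 nM 
compound 2, `CC1(c2ccc(-c3ccco3)cc2)CC(S(=O)(=O)c2ccc(F)cc2)=C(c2ccc(/C(N)=N\O)cc2)O1`, 4560 nM 

For the measured compounds named here, in an ADME assay on J774.A1 cells (Mus musculus) for cytotoxicity, read by MTT assay, with a stated time of 72 h (on this read-out higher numbers stand for lower toxicity in this test and lower numbers for higher toxicity in this test), compound 2 gives the lowest of the two numbers; compound 1 stands at a higher number, a gap beyond the scatter, though no single-point step between the two is defined. Compound 3, `COc1cc(-c2ccc(C3(C)CC(S(=O)(=O)c4ccc(F)cc4)=C(c4ccc(/C(N)=N\O)cc4)O3)cc2)cc(OC)c1OC`, differs from compound 2 by 3,4,5-trimethoxyphenyl in place of furan-2-yl on an aromatic carbon, para to a large group. Going by the values given here, with no comparable step the direction is open; a step of at most moderate size is expected, leaning toward a somewhat lower number, a 1.3-fold lower number from compound 2 to compound 3 (0.11 log units; within the scatter). For compound 3 the estimate is 3500 nM, expected between 1200 nM and 11000 nM.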

Compound 3, half-maximal cytotoxic concentration: 5220 nM
Estimate against measurement, compound 3: 1.5-fold (0.17 log units) below, within the range that was stated.
By their numbers in this assay, from the lowest: compounds 2 and 3 (each within the scatter of the next); then compound 1.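

In this assay, 3,4,5-trimethoxyphenyl in place of furan-2-yl on an aromatic carbon, para to a large group, gives a 1.1-fold higher number from compound 2 to compound 3 (0.06 log units; within the scatter). This first single-place comparison in the series shows that this position accepts the larger trimethoxyphenyl group with no difference beyond the scatter in this test. No measurement available here offers an explanation for this result.

On these data alone, whether an amine or a carboxylic acid at this carbon would also stay within the scatter of compound 2 remains open. A single step cannot show whether the same holds for other changes on the shared core.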